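Notes on compound 4: 2-methylphenyl for 4-methylphenyl

The source may report more compounds than this note shows. Statements on the series, on what has been measured and on what is new or still open speak of the compounds shown alone.

Measured so far in an ADME assay on HEK293 cells (Homo sapiens) for cytotoxicity, read by resazurin assay, with a stated time of 48 h (a lower number here means that less compound is tolerated, a higher number that more compound is tolerated), as follows
compound 1 `O=S(=O)(Nc1ccc(-c2nc3ccccc3o2)cc1)c1cccc(F)c1` gives > 100000 nM (a limit of the assay)
compound 2 `Cc1ccc(S(=O)(=O)Nc2ccc(-c3nc4ccccc4o3)cc2)cc1` gives 88000 nM
compound 3 `Cc1ccc(S(=O)(=O)Nc2ccc3oc(-c4ccccc4)nc3c2)cc1` gives 75000 nM

In this assay compound 3 (75000 nM) lies within the usual scatter of compound 2 (88000 nM). The value of compound 1 is a limit and not a number (the limit of > 100000 nM in this assay, at which 1 of the 3 values shown sits). For the measured compounds named here, these two numbers are therefore the only ones against which compound 3 can be placed.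

Compound 4 `Cc1ccccc1S(=O)(=O)Nc1ccc2oc(-c3ccccc3)nc2c1` differs from compound 3 by 2-methylphenyl in place of 4-methylphenyl on a sulfonyl sulfur. Going by the values given here, the only measured step at that sulfonyl sulfur (an at least 1.1-fold lower number from compound 1 to compound 2 (0.05 log units; that floor lies within the scatter)) is a different exchange, and its floor lies within the scatter. Among the compounds with values here, no measured pair compares 2-methylphenyl with 4-methylphenyl directly, so the expectation rests on that one step and on the value of compound 3 (75000 nM). No step beyond the scatter is expected in this assay, and neither direction is favoured. The estimated change is small (no change at the digits printed from compound 3 to compound 4 (within the scatter)). For compound 4 the expected value is 75000 nM with an estimated range (40000 nM to 100000 nM).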

Compound 4, half-maximal cytotoxic concentration: 57000 nM
Compound 4: middle estimate off by 1.3-fold (0.12 log units), on the high side; the range from low to high includes it.
By their numbers in this assay, from the lowest: compounds 4, 3 and 2 (each within the scatter of the next). At a limit, above all of these: compound 1.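

In this assay, 2-methylphenyl in place of 4-methylphenyl on a sulfonyl sulfur gives a 1.3-fold lower number from compound 3 to compound 4 (0.12 log units; within the scatter). For the compounds shown here, this is the first direct comparison of these two groups at this place, and with the same atoms joined differently, the pair cannot be told apart in this assay. Compound 1 remains a limit and not a number, so its step to compound 2 still gives only a floor: the limit of > 100000 nM in this assay, at which 1 of the 4 values shown sits.

The compounds shown leave open whether any group on the sulfonyl sulfur can move the number in this assay beyond the scatter, since a phenyl carrying an amine or a carboxylic acid, or a group without an aromatic ring such as a longer alkyl chain, is not among them. They also leave open whether 3-fluorophenyl, which sits on the core of compound 1, would give a limit on the core of compound 3 as well, as no pair shown compares that group with either methylphenyl group on that core.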